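Side-chain exchange on the shared core: compound 1 to compound 4

A few compounds are considered here, and "the series" means these few. Any claim that something is new, unique, unknown or untested is made for them only; others in the source may bear on it.

Measured so far in a functional assay on HCT-116 cells (Homo sapiens) for inhibition, read by sulforhodamine B assay, with a stated time of 48 h; a higher number here means a weaker inhibitor, a lower number a stronger inhibitor:
compound 1 `CCOC(=O)C(C)C(O)(c1ccc(OC)c(OC)c1OC)c1cccc2ccccc12` — > 20000 nM
compound 2 `COc1ccc(/C(=N/OC(C)=O)c2cccc3ccccc23)c(OC)c1OC` — 4980 nM
compound 3 `COc1ccc(/C(=N/O)c2cccc3ccccc23)c(OC)c1OC` — 5880 nM

The entry for compound 1 is a limit of the assay and not a number. Compound 1 sits at the limit of > 20000 nM in this assay, at which 1 of the 3 values shown sits. Compounds 2 and 3 carry an oxime in place of the tertiary alcohol of compound 1, and their numbers lie close together: a 1.2-fold higher number from compound 2 to compound 3 (0.07 log units; within the scatter). That single measured step, hydrogen in place of acetyl on an oxygen, leaves the carbon that is altered below untouched, so it gives no direct guide to the change at hand.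

Compound 4 `COc1ccc(C(O)(Cc2ccc(C)cc2)c2cccc3ccccc23)c(OC)c1OC` differs from compound 1 by 4-methylbenzyl in place of 1-(ethoxycarbonyl)ethyl on a saturated chain carbon bound to two aromatic carbons and an oxygen on a saturated carbon. Going by the values given here, no measured step concerns this position, and the only number for compound 1 is a limit, so the direction of the step cannot be read from the series. The expected step is an at least 1.3-fold lower number from compound 1 to compound 4 (0.12 log units; that floor lies within the scatter), stated with low confidence. Compound 4 is expected to give 15000 nM in this assay, with a range from 3000 nM to 60000 nM, and a fair chance that only a limit is again reported.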

Compound 4, half-maximal inhibitory concentration: > 20000 nM
Compound 4 was reported as a limit; the forecaster's own chance of this, stated with the estimate: 45%; middle value at least 1.3-fold (0.12 log units) from the limit.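

Compound 1 and compound 4 are both reported only as limits of the assay and not as numbers in this assay, so no step can be read between them: the limit of > 20000 nM in this assay, at which 2 of the 4 values shown sit.

The compounds shown leave open the size and direction of any effect of 4-methylbenzyl in place of 1-(ethoxycarbonyl)ethyl on this saturated chain carbon.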